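The source may report more compounds than this note shows. Statements on the series, on what has been measured and on what is new or still open speak of the compounds shown alone.

Compound 1 `Cc1ncnc2c1c(-c1cccs1)cn2[C@@H]1O[C@H](CO)[C@@H](O)[C@H]1O` gives > 20000 nM in a functional assay on K562 cells (Homo sapiens), read by MTT assay, with a stated time of 72 h (on this read-out higher numbers stand for weaker inhibition and lower numbers for stronger inhibition), which is a limit of the assay rather than a number. Compound 2 `CN(C)c1ncnc2c1c(-c1cc3ccccc3o1)cn2[C@@H]1O[C@H](CO)[C@@H](O)[C@H]1O` gives > 20000 nM in this assay, likewise a limit. Compound 3 `C#Cc1cn([C@@H]2O[C@H](CO)[C@@H](O)[C@H]2O)c2ncnc(N(C)C)c12` gives 260 nM in this assay.

Compound 2 thus stands at the limit (the limit of > 20000 nM in this assay, at which 2 of the 3 values shown sit), together with compound 1, while compound 3 is the only one of the three with a number. For the measured compounds named here, the one measured step, an at least 76-fold lower number from compound 2 to compound 3 (1.88 log units; beyond the scatter), concerns a different position and so does not bear on the change toward compound 4 `Cc1ncnc2c1c(-c1cc3ccccc3o1)cn2[C@@H]1O[C@H](CO)[C@@H](O)[C@H]1O`, which is methyl in place of dimethylamino on an aromatic carbon. Going by the values given here, compound 1 carries the same methyl at that position and sits at the limit, but it differs from compound 2 in a second place as well, so no single-change step is available. With nothing pointing toward a stronger inhibition, compound 4 is expected to stay at the limit as well. The estimate for compound 4 is 30000 nM, with a range from 10000 nM to 100000 nM. The step this estimate implies, a step that the limit leaves unreadable from compound 2 to compound 4, is expected to lie within the scatter.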

Compound 4, half-maximal inhibitory concentration: > 20000 nM
Compound 4: only a limit was reported; the forecaster's own chance of this, stated with the estimate: 85%; the middle value lies beyond the limit too.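

Compound 4 gives > 20000 nM in this assay, again a limit, so its steps from compound 1 and from compound 2 cannot be read: the limit of > 20000 nM in this assay, at which 3 of the 4 values shown sit. The compounds shown leave open whether methyl and dimethylamino, or 1-benzofuran-2-yl and thiophen-2-yl, differ at all in this assay.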